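A few compounds are considered here, and "the series" means these few. Any claim that something is new, unique, unknown or untested is made for them only; others in the source may bear on it.

- compound 1 `C=C1C(=O)[C@@]23C(=O)OC[C@]4(C(=O)CCC(C)(C)[C@H]4C=O)[C@@H]2CC[C@@H]1[C@H]3O` at 5850 nM
- compound 2 `C=C1C(=O)[C@@]23C(=O)OC[C@]4(C(=O)CCC(C)(C)[C@H]4C=O)[C@@H]2CC[C@@H]1[C@H]3OC(=O)CC` at 1400 nM
- compound 3 `C=C1C(=O)[C@@]23C(=O)OC[C@]4(C(=O)CCC(C)(C)[C@H]4C=O)[C@@H]2CC[C@@H]1[C@H]3OC(=O)c1ccc(C)cc1` at 1050 nM

In a functional assay on CaEs17 cells (Homo sapiens) for cytotoxicity, read by MTT assay, with a stated time of 72 h (on this read-out lower numbers stand for stronger inhibition and higher numbers for weaker inhibition), compound 1 carries the highest number of the three, which makes it the weakest of them. Compound 4 `C=C1C(=O)[C@@]23C(=O)OC[C@]4(C(=O)CCC(C)(C)[C@H]4C=O)[C@@H]2CC[C@@H]1[C@H]3OC(=O)c1ccc(C(F)(F)F)cc1` keeps the core of compound 1 and changes one place. The change (4-(trifluoromethyl)phenyl)carbonyl in place of hydrogen on an oxygen on a saturated carbon puts (4-(trifluoromethyl)phenyl)carbonyl in place of hydrogen on an oxygen on a saturated carbon.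

Two measured changes at that same oxygen bear on this one. Propanoyl gave a 4.2-fold lower number from compound 1 to compound 2 (0.62 log units; beyond the scatter) and (4-methylphenyl)carbonyl gave a 5.6-fold lower number from compound 1 to compound 3 (0.75 log units; beyond the scatter) as the nearer model, since it shares the ring of the new group. Between these two groups the difference is only a 1.3-fold lower number from compound 2 to compound 3 (0.12 log units; within the scatter) and so the kind of group has shown little effect so far. Going by the values given here, no measured compound carries a trifluoromethyl group, so the range stays wide.

A modest step to a lower number is expected, estimated as a 5.3-fold lower number from compound 1 to compound 4 (0.73 log units; beyond the scatter) in this assay and similar in size to those two. Compound 4 is estimated at 1100 nM with 500 nM to 2400 nM as the expected range.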

Compound 4, half-maximal inhibitory concentration: 8960 nM
Estimate against measurement, compound 4: 8.1-fold (0.91 log units) below; measured number above the stated range.
By their numbers in this assay, from the lowest: compounds 3 and 2 (each within the scatter of the next); then compounds 1 and 4 (each within the scatter of the next).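

At this oxygen, adding a group does not by itself lower the number in this assay: (4-(trifluoromethyl)phenyl)carbonyl in place of hydrogen gives a 1.5-fold higher number from compound 1 to compound 4 (0.19 log units; within the scatter) and so leaves the free hydroxyl compound and its derivative indistinguishable. Going by these compounds alone, the kind of group now matters, which the earlier compounds did not show: trifluoromethyl in place of methyl on an aromatic carbon gives an 8.5-fold higher number from compound 3 to compound 4 (0.93 log units; beyond the scatter) and 4-(trifluoromethyl)phenyl in place of ethyl gives a 6.4-fold higher number from compound 2 to compound 4 (0.81 log units; beyond the scatter), so the gain seen with propanoyl and (4-methylphenyl)carbonyl does not extend to every group here. Nothing available explains this difference.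

On these data alone, it remains open whether a chlorine or a methoxy group in place of the trifluoromethyl would behave like methyl or like trifluoromethyl. How a longer chain than propanoyl, or a chain ending in an amine, would fare at this oxygen is also unknown.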